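This account rests on a few compounds, and the source may have more. Where it says the series, first, only, none or still open, it means among the compounds named here.

Three members of a single series share one core, carrying different groups on the outermost ring nitrogen: compound 1 `CCNC(=O)Nc1sc2ccccc2c1C(=O)N1CCN(C2CCN(C(C)=O)CC2)CC1`, compound 2 `CCNC(=O)Nc1sc2ccccc2c1C(=O)N1CCN(C2CCN(C(=O)CC(C)C)CC2)CC1` and compound 3 `CCNC(=O)Nc1sc2ccccc2c1C(=O)N1CCN(C2CCN(C(=O)C3CCCC3)CC2)CC1`. In a functional assay on HepG2 cells (Homo sapiens) for inhibition, read by scintillation counting, with a stated time of 2 h (on this read-out lower numbers stand for stronger inhibition and higher numbers for weaker inhibition), compound 1 gives "not determined" (no result reported) and compound 2 gives "not determined" (no result reported), so for neither of these two was a result reported. Within the data shown here, compound 3 is thus the only one with a number: in this assay compound 3 gives 309 nM, and no comparison to another measured compound can be drawn from it. Compound 4 `CCNC(=O)Nc1sc2ccccc2c1C(=O)N1CCN(C2CCN(C(=O)OC3CCCC3)CC2)CC1` differs from compound 3 in a single place: cyclopentyloxy in place of cyclopentyl on a carbonyl carbon. Among the measured compounds shown here, with no measured step available to guide this change, the move from compound 3 to compound 4 is expected to stay within the usual scatter, with a 1.3-fold higher number from compound 3 to compound 4 (0.11 log units; within the scatter) as the estimated step. Compound 4 is therefore estimated to give 400 nM, with a likely range from 150 nM to 1200 nM.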

Compound 4, half-maximal inhibitory concentration: 512 nM
Estimate against measurement, compound 4: 1.3-fold (0.11 log units) below; measured number inside the range.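

Among these compounds, the change from cyclopentyl to cyclopentyloxy on a carbonyl carbon provides the first measured step at this position (a 1.7-fold higher number from compound 3 to compound 4 (0.22 log units; within the scatter)) in this assay. Compound 3 and compound 4 therefore cannot be told apart on this read-out, so this position accepts the swap from cyclopentylcarbonyl to cyclopentyloxycarbonyl with no change beyond the scatter. No evidence is available that bears on this result.

The compounds shown leave open how a cyclopentylamino group, with nitrogen in place of the added oxygen, would read here. They also leave open what a carboxylic acid or a longer chain at this position would give.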